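One More Ring Swap on a Shared Core

This account rests on a few compounds, and the source may have more. Where it says the series, first, only, none or still open, it means among the compounds named here.

In a physicochemical assay for solubility, in phosphate buffer, at pH 7.4 (on this read-out higher numbers stand for higher solubility and lower numbers for lower solubility), compound 1 (`CC(=O)N[C@@H]1CCC[C@H](C(=O)Nc2cc(-c3cnn(C)c3C)c(Cl)cn2)C1`) gives 960000 nM and compound 2 (`CC(=O)N[C@@H]1CCC[C@H](C(=O)Nc2cc(-c3nnn4ccccc34)c(Cl)cn2)C1`) gives 530000 nM while compound 3 (`CC(=O)N[C@@H]1CCC[C@H](C(=O)Nc2cc(-c3cnc4n3CCC4)c(Cl)cn2)C1`) gives 490000 nM on the same scale. Compound 3 lies within the scatter of both other compounds, so these three numbers cannot be ranked.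

Compound 4 (`CC(=O)N[C@@H]1CCC[C@H](C(=O)Nc2cc(-c3cnn4c3CN(C)CC4)c(Cl)cn2)C1`) differs from compound 3 at one place, an aromatic carbon ortho to a chloro group. The change is a group of 10 heavy atoms (7 carbon, 3 nitrogen; one five-membered aromatic ring with 2 hetero atoms, one six-membered non-aromatic ring with 2 hetero atoms) in place of a group of 8 heavy atoms (6 carbon, 2 nitrogen; one five-membered non-aromatic ring with 1 hetero atom, one five-membered aromatic ring with 2 hetero atoms), on an aromatic carbon on that carbon.

Three measured exchanges at this carbon bear on it: a 1.8-fold lower number from compound 1 to compound 2 (0.26 log units; within the scatter) and a 2.0-fold lower number from compound 1 to compound 3 (0.29 log units; within the scatter) and a 1.1-fold lower number from compound 2 to compound 3 (0.03 log units; within the scatter) all stay within the scatter. Among the compounds with values here, none of those groups carries a six-membered non-aromatic ring with 2 hetero atoms, so the new group has no direct precedent. Even so, the step in this assay is expected to stay within the scatter, in no firm direction. The estimated step is a 1.2-fold higher number from compound 3 to compound 4 (0.09 log units; within the scatter) and no larger claim is made. Compound 4 is expected to give about 600000 nM with a range from 280000 nM to 1200000 nM as the estimate.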

Compound 4, solubility: 870000 nM
The estimate for compound 4 lay 1.5-fold (0.16 log units) below the measured number; the range from low to high includes it.
By their numbers in this assay, from the lowest: compounds 3, 2, 4 and 1 (each within the scatter of the next).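

Placing the group with a six-membered non-aromatic ring with 2 hetero atoms on this aromatic carbon, ortho to a chloro group, gives a 1.8-fold higher number from compound 3 to compound 4 (0.25 log units; within the scatter), a 1.6-fold higher number from compound 2 to compound 4 (0.22 log units; within the scatter) and a 1.1-fold lower number from compound 1 to compound 4 (0.04 log units; within the scatter) in this assay, and all three steps stay within the scatter. The earlier compounds shown here carried no such ring, and with it the four groups at this carbon, which range from 7 to 10 heavy atoms, still cannot be ranked against one another. Nothing measured here offers an explanation for these numbers.

As far as these compounds go, whether a carboxylic acid or an open chain ending in an amine on this carbon would move the number beyond the scatter remains open. So does whether these four groups would also stay unranked on any other read-out.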